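Two Limit Values and a Trifluoromethyl Variant

This account rests on a few compounds, and the source may have more. Where it says the series, first, only, none or still open, it means among the compounds named here.

Compound 1 `COc1ccccc1CNc1ncnc2c1ncn2[C@@H]1O[C@H](CO)[C@@H](O)[C@H]1O` was tested in a functional assay on MCF cells (Homo sapiens) for antiproliferative activity, with a stated time of 72 h; a higher number here means a weaker inhibitor, a lower number a stronger inhibitor. In this assay compound 1 returns > 166000 nM, which is a limit of the assay rather than a number. Compound 2 `OC[C@H]1O[C@@H](n2cnc3c(NCc4cc(F)cc(F)c4)ncnc32)C(O)C1O` also gives in this assay > 166000 nM, again a limit. Both readings therefore sit at the limit of > 166000 nM in this assay, at which 2 of the 2 values shown sit, so compound 1 stands at the edge of what the assay reports. Compound 3 `OC[C@H]1O[C@@H](n2cnc3c(NCc4ccc(C(F)(F)F)cc4)ncnc32)[C@H](O)[C@@H]1O` differs from compound 1 by 4-(trifluoromethyl)phenyl in place of 2-methoxyphenyl on a saturated chain carbon bound to a nitrogen on an aromatic ring. Going by the values given here, with no measured step in this set, the change is expected to bring a step that the limit leaves unreadable from compound 1 to compound 3, nothing beyond the scatter. Compound 3 is thus estimated at 200000 nM, within 50000 nM to 800000 nM.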

Compound 3, half-maximal inhibitory concentration: > 166000 nM
Compound 3 gave a limit, no number (the forecaster's own chance of this, stated with the estimate: 85%); the middle value does not contradict the limit.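

Compound 1 and compound 3 both end at a limit, so no step between them can be read in this assay: the limit of > 166000 nM in this assay, at which 3 of the 3 values shown sit.

The compounds shown leave open whether 4-(trifluoromethyl)phenyl in place of 2-methoxyphenyl changes antiproliferative activity at all.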